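Benzyl in place of 2-methoxyphenyl on the amide-type nitrogen

This account rests on a few compounds, and the source may have more. Where it says the series, first, only, none or still open, it means among the compounds named here.

- compound 1 (`CCc1ccc(NC(=O)C2CCN(C/C=C/c3ccccc3)CC2)cc1`) gives 19600 nM
- compound 2 (`COc1ccccc1NC(=O)C1CCN(C/C=C/c2ccccc2)CC1`) gives > 100000 nM as a limit
- compound 3 (`O=C(Nc1cc(-c2cccc(Br)c2)on1)C1CCN(C/C=C/c2ccccc2)CC1`) gives 6530 nM

All three results come from a functional assay on A549 cells (Homo sapiens) for inhibition, read by MTT assay, with a stated time of 72 h (a higher number here means a weaker inhibitor, a lower number a stronger inhibitor), and form the whole basis for these notes. For compound 2 the record is the limit of > 100000 nM in this assay, at which 1 of the 3 values shown sits, and it is a limit, not a number. Compound 4 (`O=C(NCc1ccccc1)C1CCN(C/C=C/c2ccccc2)CC1`) differs from compound 2 by benzyl in place of 2-methoxyphenyl on an amide-type nitrogen and so carries benzyl in place of 2-methoxyphenyl on an amide-type nitrogen.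

The measured step that bears on this is an at least 5.1-fold higher number from compound 1 to compound 2 (0.70 log units; beyond the scatter) and it lies beyond the scatter, with 2-methoxyphenyl in place of 4-ethylphenyl on an amide-type nitrogen. As 2-methoxyphenyl leaves again in compound 4, a move to a lower number in this assay is expected. Compound 1 at 19600 nM and compound 3 at 6530 nM both give numbers rather than a limit, with other groups on that nitrogen. Benzyl itself has not been measured on the shared core, so the size remains loose. The expected change is an at least 3.3-fold lower number from compound 2 to compound 4 (0.52 log units; beyond the scatter) and it should be modest rather than large. For compound 4 the expected range is 9000 nM to 90000 nM and the estimated value 30000 nM lies within it.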

Compound 4, half-maximal inhibitory concentration: > 100000 nM
Compound 4: a limit, no number; the forecaster's own chance of this, stated with the estimate: 20%; middle value at least 3.3-fold (0.52 log units) away from the limit.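

Benzyl in place of 4-ethylphenyl on the amide-type nitrogen gives an at least 5.1-fold higher number from compound 1 to compound 4 (0.70 log units; beyond the scatter) in this assay, in the same direction as an at least 5.1-fold higher number from compound 1 to compound 2 (0.70 log units; beyond the scatter), so the drop to a limit is not confined to 2-methoxyphenyl. The step from compound 2 to compound 4 cannot be read, as both ends are limits, and any real difference between benzyl and 2-methoxyphenyl stays hidden. The methoxy oxygen leaves with 2-methoxyphenyl, yet the record at this position stays the same: the limit of > 100000 nM in this assay, at which 2 of the 4 values shown sit.

Among the four groups on this nitrogen, only compound 1 at 19600 nM and compound 3 at 6530 nM give numbers in this assay, and these two go against any reading that the position simply tolerates no group, while the shared features of their groups remain unresolved by so few examples. Open too, as far as these compounds go, is whether a longer chain such as butyl in place of the ethyl of 4-ethylphenyl, or an amine or a carboxylic acid there, would keep a number or fall to the limit.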